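Aryl selenocyanate carbamates: phenyl for propyl on the ester chain

This account rests on a few compounds, and the source may have more. Where it says the series, first, only, none or still open, it means among the compounds named here.

Compound 1 `CCCCOC(=O)Nc1ccc([Se]C#N)cc1` carries a selenocyanate on the shared core with a carbamate ester. In a functional assay on HT-29 cells (Homo sapiens) for cytotoxicity, read by MTT assay, with a stated time of 72 h (a lower number here means a stronger inhibitor of growth, a higher number a weaker inhibitor of growth), compound 1 gives 8100 nM. Among the compounds with values here, the only other measured member, the diselenide compound 2 `Cc1ccc(OC(=O)Nc2ccc([Se][Se]c3ccc(NC(=O)Oc4ccc(C)cc4)cc3)cc2)cc1`, gives in this assay 7900 nM; the two values lie within the scatter of each other, so no order between compound 1 and compound 2 can be drawn, and no step between them is established.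

Compound 3 `N#C[Se]c1ccc(NC(=O)OCc2ccccc2)cc1` has not yet been measured. It differs from compound 1 by phenyl in place of propyl on a saturated chain carbon bound to an oxygen next to a carbonyl group. The selenocyanate and the carbamate of compound 1 remain in place; the replacement of the propyl by the phenyl touches only the ester chain. Within the data shown here, with no step of this kind measured, the expectation for compound 3 is a step from compound 1 within the scatter of this assay, in no firm direction: the estimated change is a 1.2-fold lower number from compound 1 to compound 3 (0.10 log units; within the scatter). For compound 3 the expected value in this assay is therefore 6500 nM, with a range from 2000 nM to 20000 nM.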

Compound 3, concentration for 50% growth inhibition: 13300 nM
For compound 3 the middle estimate is 2.0-fold (0.31 log units) below the measured one; the range from low to high includes it.
By their numbers in this assay, from the lowest: compounds 2, 1 and 3 (each within the scatter of the next).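

In this assay, phenyl in place of propyl on a saturated chain carbon bound to an oxygen next to a carbonyl group gives a 1.6-fold higher number from compound 1 to compound 3 (0.22 log units; within the scatter), the first step read at this position. This step lies within the scatter, so compound 1 and compound 3 cannot be ordered, and the exchange of a saturated chain for an aromatic ring shows no measurable effect on growth inhibition here. No measurement bears on the reason for the size of this step.

On these data alone, whether a longer chain, or a phenyl carrying an amine or a carboxylic acid, would give a step beyond the scatter at this position remains open. Compound 2 differs from compound 1 and compound 3 in more than one place, so the contribution of the selenocyanate also remains unresolved.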